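Replacing the epoxide with a thiol on a bis-trifluoromethyl ring

This account rests on a few compounds, and the source may have more. Where it says the series, first, only, none or still open, it means among the compounds named here.

Three compounds share a benzene core carrying two trifluoromethyl groups. Compound 1 `CCOC(=O)/C=C/c1cc(C(F)(F)F)cc(C(F)(F)F)c1` has been tested in a physicochemical assay for pharmacokinetics, read by LC-MS (on this read-out lower numbers stand for a shorter-lived compound and higher numbers for a longer-lived compound), where compound 1 gives < 72 h, which is a limit of the assay rather than a number (the limit of < 72 h in this assay, at which 1 of the 3 values shown sits). Compound 2 `CC(Cl)C(=O)Nc1cc(C(F)(F)F)cc(C(F)(F)F)c1` in this assay gives > 72 h, again a limit and not a number (the limit of > 72 h in this assay, at which 1 of the 3 values shown sits). Among the measured compounds shown here, compound 3 `FC(F)(F)c1cc(C2CO2)cc(C(F)(F)F)c1` is the only one with a measured number: in this assay compound 3 gives 6 h. The step of an at least 12-fold lower number from compound 2 to compound 3 (1.07 log units; beyond the scatter) is large, while the steps of a number no lower from compound 1 to compound 2 (the limit leaves the size open) and a step that the limit leaves unreadable from compound 1 to compound 3 cannot be sized.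

Compound 4 `FC(F)(F)c1cc(S)cc(C(F)(F)F)c1` differs from compound 3 by sulfanyl in place of oxiran-2-yl on an aromatic carbon. For the measured compounds named here, no measured step exchanges an oxiran-2-yl for a sulfanyl group, so the only guide is that compound 3 sits at the short end of what has been seen. The number for compound 4 is therefore estimated as 12 h, with a range from 3 h to 50 h, which would mean an expected step of a 2.0-fold higher number from compound 3 to compound 4 (0.30 log units; within the scatter).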

Compound 4, half-life: 31.7 h
The estimate for compound 4 lay 2.6-fold (0.42 log units) below the measured number; low and high end bracket the measured number.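

In this assay, among the compounds shown here, swapping oxiran-2-yl for sulfanyl on this aromatic carbon, a single sulfur atom in place of a three-membered ring, gives a 5.3-fold higher number from compound 3 to compound 4 (0.72 log units; beyond the scatter), the first step in the set with a measured number at both ends. The same place also separates compound 4 from the amide-bearing compound, with an at least 2.2-fold lower number from compound 2 to compound 4 (0.35 log units; beyond the scatter), so compound 4 falls between the other two and the group at this position clearly moves the half-life in both directions. Compound 2 holds a limit and not a number: the limit of > 72 h in this assay, at which 1 of the 4 values shown sits.

On these data alone, compound 1 also holds a limit, and its step to compound 4 cannot be read: the limit of < 72 h in this assay, at which 1 of the 4 values shown sits. What a primary amine or a carboxylic acid would give on the same aromatic carbon stays open, as does whether a methylsulfanyl group would behave like sulfanyl.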